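Swapping Phenyl for Benzothiophene on a Shared Core

The source may hold more compounds than are shown below. What is called first, only, known or untested is meant among the compounds shown, and "the series" means these compounds.

Of the compounds shown here, two have been measured so far. Compound 1 `CCOC(=O)c1cnc(N(Cc2ccccc2)N2C(=O)C=C(C)C2=O)nc1C(F)(F)F` carries a trifluoromethyl group and a benzyl group; in a functional assay on Jurkat cells (Homo sapiens) for inhibition (a lower number here means a stronger inhibitor, a higher number a weaker inhibitor), compound 1 gives 450 nM. Compound 2 `CCOC(=O)c1cnc(NN2C(=O)C=C(C)C2=O)nc1-c1ccccc1` carries a phenyl group instead; in this assay compound 2 gives 1200 nM. Compound 2 therefore stands with the higher of the two numbers, meaning the weaker inhibitor of the pair, and the gap to compound 1 lies beyond the usual scatter. Because the two compounds differ in more than one place, no single change can be held responsible for that gap.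

Compound 3 `CCOC(=O)c1cnc(NN2C(=O)C=C(C)C2=O)nc1-c1cc2ccccc2s1` is the next compound, not yet measured. It differs from compound 2 in exactly one place: 1-benzothiophen-2-yl in place of phenyl on an aromatic carbon. Within the data shown here, no measured pair shows what this kind of swap does on this core, so any expectation rests on the single starting number alone. The step is expected to be a 1.5-fold lower number from compound 2 to compound 3 (0.18 log units; within the scatter), a modest shift with no direction that can be claimed beyond the scatter. Compound 3 is accordingly estimated at 800 nM, with a plausible range from 250 nM to 3000 nM.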

Compound 3, half-maximal inhibitory concentration: 800 nM
The estimate for compound 3 equals the measured number at the digits printed; low and high end bracket the measured number.
By their numbers in this assay, from the lowest: compounds 1, 3 and 2 (each within the scatter of the next, the first and the last beyond it).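

Among these compounds, this is the first step on the shared core that can be read in one place, the aromatic carbon next to the ring nitrogen and ortho to an ethoxycarbonyl group. In this assay the change from phenyl to 1-benzothiophen-2-yl gives a 1.5-fold lower number from compound 2 to compound 3 (0.18 log units; within the scatter) and so leaves the two compounds indistinguishable, even though the group entering has 9 heavy atoms against 6, a second aromatic ring and a sulfur. At this position, then, a two-ring aromatic group and a single phenyl ring give numbers that cannot be told apart, and nothing available explains why the read-out stays put.

On these data alone, one step with one pair of groups says little about the position as a whole, so it remains open whether a small group such as methyl, an amine or a carboxylic acid at this carbon would move the number beyond the scatter. As far as these compounds go, compound 1 carries trifluoromethyl at this carbon but also has a benzyl group on the linking nitrogen, so the separate contribution of each of those two groups remains open as well.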